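The source may hold more compounds than are shown below. What is called first, only, known or untested is meant among the compounds shown, and "the series" means these compounds.

Measured compounds:
compound 1, `COc1ccc(OC)c(/C=C/c2nnc(Nc3ccc(Cl)cc3)o2)c1`: 1870 nM
compound 2, `COc1ccc(OC)c(/C=C/C(=O)N/N=C/c2ccc(Cl)cc2)c1`: 182 nM

Two compounds share the dimethoxystyryl part and differ in what follows it. In a functional assay on A498 cells (Homo sapiens) for antiproliferative activity, read by sulforhodamine B assay, with a stated time of 48 h (on this read-out higher numbers stand for weaker inhibition of growth and lower numbers for stronger inhibition of growth), compound 1 gives 1870 nM, while in this assay compound 2 gives 182 nM. Within the data shown here, compound 2 therefore stands at the lower of the two numbers, and its gap to compound 1 is well beyond the scatter; no single-point step between these two is described, so only their values are compared here.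

Compound 3, `COc1ccc(OC)c(/C=C/C(=O)N/N=C/c2ccccc2)c1`, has not been measured in this assay. Relative to compound 2, the change is hydrogen in place of chloro on an aromatic carbon. Among the measured compounds shown here, no step of this kind between measured compounds is available, so the expectation rests on compound 2 alone. Given that compound 2 shows 182 nM, the step is expected to be small, toward a somewhat higher number, and possibly not beyond the scatter, so that the estimated step is a 1.8-fold higher number from compound 2 to compound 3 (0.25 log units; within the scatter). Compound 3 is therefore estimated at 320 nM in this assay, with an expected range from 120 nM to 850 nM.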

Compound 3, concentration for 50% growth inhibition: 12000 nM
Beside the measured number, compound 3's estimate is 38-fold (1.57 log units) below it; the whole stated range lies below it.
By their numbers in this assay, from the lowest: compound 2; then compound 1; then compound 3.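

In this assay, the chloro of compound 2 proves far from incidental: exchanging it for hydrogen gives a 66-fold higher number from compound 2 to compound 3 (1.82 log units; beyond the scatter), so this single atom on an aromatic carbon, para to a large group, separates a strong growth inhibitor from a much weaker one. Among these compounds, the earlier compounds could not show this, since compound 1 and compound 2 differ in more than one place and offered no step that isolated any single position; this is the first direct reading of the 4-chlorophenyl to phenyl change. No measurement at hand explains why the loss is so large.

The compounds shown leave open whether the gain belongs to chloro in particular or would also appear with fluoro, bromo, methyl, methoxy or an amine on the same carbon. They also leave open whether the same exchange of chloro for hydrogen would have a comparable effect on the 4-chlorophenyl group of compound 1, where a different part follows the dimethoxystyryl group.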